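Moving the fluorine on the benzyl group of compound 3

The source may report more compounds than this note shows. Statements on the series, on what has been measured and on what is new or still open speak of the compounds shown alone.

Compound 3 `O=C(C1CC1)N1CCN(Cc2nc3ccccc3n2Cc2cccc(F)c2)CC1` gives 27.2% in an assay on isolated protein for inhibition of aldehyde dehydrogenase 1A1 (Homo sapiens), read by spectrophotometry, tested at 10 uM (on this read-out lower numbers stand for less inhibition and higher numbers for more inhibition at the one concentration tested (going by the name of the read-out)), the lowest of the three numbers seen so far. Compound 1 `Cc1cccc(Cn2c(CN3CCN(C(=O)c4ccc(C(C)C)cc4)CC3)nc3ccccc32)c1` gives 67.6% in this assay, and compound 2 `Cc1cccc(Cn2c(CN3CCN(C(=O)c4cccs4)CC3)nc3ccccc32)c1` gives 60.8% in this assay; both stand beyond the scatter above compound 3. Going by the values given here, the only measured step, a number 6.8 percentage points lower from compound 1 to compound 2 (within the scatter), concerns a change on a carbonyl carbon and lies within the scatter. Compound 4 `O=C(C1CC1)N1CCN(Cc2nc3ccccc3n2Cc2ccc(F)cc2)CC1` differs from compound 3 by 4-fluorophenyl in place of 3-fluorophenyl on a saturated chain carbon bound to an aromatic nitrogen. Among the compounds with values here, no measured step bears on this change, so the expectation for compound 4 is a step of a number 0.2 percentage points lower from compound 3 to compound 4 (within the scatter), none beyond the scatter. Compound 4 is therefore estimated at 27% in this assay, with a range from 10% to 45%.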

Compound 4, a percentage reported as inhibition, at one concentration (the size of the read-out at that concentration, not a potency): 32.7%
Compound 4: middle estimate off by 5.7 percentage points, on the low side; low and high end bracket the measured number.
By their numbers in this assay, from the lowest: compounds 3 and 4 (each within the scatter of the next); then compounds 2 and 1 (each within the scatter of the next).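

In this assay, going by these compounds alone, the change from 3-fluorophenyl to 4-fluorophenyl on a saturated chain carbon bound to an aromatic nitrogen comes to a number 5.5 percentage points higher from compound 3 to compound 4 (within the scatter) and gives the first measured step at this position. Between these two groups, the place of the fluorine does not separate the compounds. Nothing measured here explains this result.

As far as these compounds go, an amine or a carboxylic acid in place of the fluorine remains open. So does whether the same change reads alike with thiophen-2-yl on the carbonyl carbon.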